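The source may report more compounds than this note shows. Statements on the series, on what has been measured and on what is new or still open speak of the compounds shown alone.

Compound 3, `CC(C)(C)CC(C)(C)Nc1c(-c2ccc(Br)cc2)nc2ncccn12`, stands at the highest of the two numbers found in a toxicity assay on A549 cells (Homo sapiens) for cytotoxicity, read by luminescence and CellTiter-Glo, with a stated time of 48 h (on this read-out lower numbers stand for higher toxicity in this test and higher numbers for lower toxicity in this test), where compound 3 gives 32000 nM. Its nearest neighbour is compound 1, `CCCCOc1ccc(-c2nc3ncccn3c2NC(C)(C)CC(C)(C)C)cc1`, for which this assay gives 29000 nM; the two differ by a 1.1-fold higher number from compound 1 to compound 3 (0.04 log units; within the scatter). Compound 2, `CCCCOc1ccc(-c2nc3ncccn3c2N)cc1`, is the compound whose number in this assay is a limit, > 100000 nM, and not a number, as recorded at the limit of > 100000 nM in this assay, at which 1 of the 3 values shown sits.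

Compound 4, `Nc1c(-c2ccc(Br)cc2)nc2ncccn12`, differs from compound 3 by a single change: hydrogen in place of 1,1,3,3-tetramethylbutyl on a nitrogen on an aromatic ring. The same change has been measured once on this series, from compound 1 to compound 2, where it brought an at least 3.4-fold higher number from compound 1 to compound 2 (0.53 log units; beyond the scatter). That step is the only one that bears directly on the move to compound 4, and it points towards a higher number, of a size that can only be given as a lower bound, since the value for compound 2 is a limit.

Compound 4 is therefore expected to move by a 3.4-fold higher number from compound 3 to compound 4 (0.54 log units; beyond the scatter), towards a higher number in this assay. The estimate for compound 4 is 110000 nM, with a range from 60000 nM to 300000 nM, and it is thought likely that this assay will report only a limit for compound 4 rather than a number.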

Compound 4, half-maximal cytotoxic concentration: > 100000 nM
Compound 4: only a limit was reported (the forecaster's own chance of this, stated with the estimate: 70%); the middle value does not contradict the limit.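

Putting hydrogen in place of 1,1,3,3-tetramethylbutyl on the nitrogen gives an at least 3.1-fold higher number from compound 3 to compound 4 (0.49 log units; beyond the scatter) in this assay, so the change seen with butoxy on the shared core also appears with bromo in its place: the same change on two cores in this assay, an at least 3.4-fold higher number (0.53 log units; beyond the scatter) from compound 1 to compound 2 and an at least 3.1-fold higher number (0.49 log units; beyond the scatter) from compound 3 to compound 4; the limit leaves it open whether they differ

Compound 4 is recorded only as a limit, as compound 2 is, so hydrogen on this nitrogen has now twice gone with a limit and not a number: the limit of > 100000 nM in this assay, at which 2 of the 4 values shown sit.

The step from compound 2 to compound 4 cannot be read, so the swap of bromo for butoxy can be judged only with 1,1,3,3-tetramethylbutyl on the nitrogen, where it gives a 1.1-fold higher number from compound 1 to compound 3 (0.04 log units; within the scatter).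

The compounds shown leave open how far the true numbers of compound 2 and compound 4 lie past the limit, and so whether the change has the same size on both cores. They also leave open whether a smaller group on this nitrogen, such as a methyl group or a butyl chain, would give a readable number in this assay, and how much of the 1,1,3,3-tetramethylbutyl group the step depends on.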